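Ester for methyl on the pyridyl ring of an oxazole ketone

The source may report more compounds than this note shows. Statements on the series, on what has been measured and on what is new or still open speak of the compounds shown alone.

Compound 1 `Nc1ccc(-c2cnc(C(=O)CCCCCCc3ccccc3)o2)cc1`: 90 nM
Compound 2 `NC(=O)c1ccc(-c2cnc(C(=O)CCCCCCc3ccccc3)o2)cc1`: 10 nM
Compound 3 `Cc1ccc(-c2cnc(C(=O)CCCCCCc3ccccc3)o2)nc1`: 2.8 nM

In an assay (Rattus norvegicus) for inhibition of Fatty-acid amide hydrolase 1 (Homo sapiens) (a higher number here means a weaker inhibitor, a lower number a stronger inhibitor), compound 3 gives the lowest of the three numbers; compound 2 follows, and compound 1 is furthest away. Compound 4 `COC(=O)c1ccc(-c2cnc(C(=O)CCCCCCc3ccccc3)o2)nc1` differs from compound 3 by methoxycarbonyl in place of methyl on an aromatic carbon. Among the compounds with values here, no measured step swaps these two groups. The nearest guide is a 9.0-fold lower number from compound 1 to compound 2 (0.95 log units; beyond the scatter), where a carbonyl-bearing substituent replaced a small one on the same kind of position, a modest step; a 3.6-fold lower number from compound 2 to compound 3 (0.55 log units; beyond the scatter) shows a change of ring and substituent together, so it bears only loosely. A modest step in this assay, most likely downward, is therefore expected: compound 4 is estimated at 1.5 nM, between 0.4 nM and 6 nM, a step of a 1.9-fold lower number from compound 3 to compound 4 (0.27 log units; within the scatter).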

Compound 4, inhibition constant: 3.5 nM
For compound 4 the middle estimate is 2.3-fold (0.37 log units) below the measured one; low and high end bracket the measured number.
By their numbers in this assay, from the lowest: compounds 3 and 4 (each within the scatter of the next); then compound 2; then compound 1.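

In this assay, putting methoxycarbonyl in place of methyl on this aromatic carbon, two atoms from the ring nitrogen, gives a 1.3-fold higher number from compound 3 to compound 4 (0.10 log units; within the scatter). Within the data shown here, the position therefore takes the larger group, with its carbonyl and ester oxygen, without a shift beyond the scatter, something the earlier compounds, which changed ring and substituent together, could not show. Going by these compounds, whether the carboxylic acid or an amine at this place would read the same stays open, as does the effect of methoxycarbonyl on the phenyl ring of compound 1. No supporting measurement accounts for the closeness of these two numbers.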